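Hydroxy for Chloro at the End of a Chain

This account rests on a few compounds, and the source may have more. Where it says the series, first, only, none or still open, it means among the compounds named here.

Compound 1 `ClCCCc1cc[nH]n1` — in an assay for inhibition of alcohol dehydrogenase (Equus caballus), read by spectrophotometry, in the presence of a further agent that is not named here (on this read-out higher numbers stand for weaker binding and lower numbers for tighter binding), compound 1 gives 40000 nM
Compound 2 `OCc1cc[nH]n1` — in this assay compound 2 gives 150000 nM
Compound 3 `ClCc1cn[nH]c1` — in this assay compound 3 gives 2700 nM

Compound 1 stands second highest of the three numbers; compound 2 sits higher, a 3.8-fold higher number from compound 1 to compound 2 (0.57 log units; beyond the scatter), and compound 3 sits lowest of the three. Compound 4 `OCCCc1cc[nH]n1` differs from compound 1 in one place: hydroxy in place of chloro on a saturated chain carbon, three bonds along the chain from an aromatic carbon. For the measured compounds named here, the one measured step that bears on this change is the step in which hydroxy likewise entered where a chlorine-carrying chain left, a 3.8-fold higher number from compound 1 to compound 2 (0.57 log units; beyond the scatter), a modest move toward weaker binding and beyond the scatter. A modest rise of similar size in this assay is therefore expected for compound 4, a 2.5-fold higher number from compound 1 to compound 4 (0.40 log units; beyond the scatter). Compound 4 is estimated at 100000 nM, with a range from 30000 nM to 300000 nM.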

Compound 4, dissociation constant: 60000 nM
Beside the measured number, compound 4's estimate is 1.7-fold (0.22 log units) above it; low and high end bracket the measured number.
By their numbers in this assay, from the lowest: compound 3; then compounds 1 and 4 (each within the scatter of the next); then compound 2.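

At the end of this chain, hydroxy and chloro cannot be told apart in this assay, a 1.5-fold higher number from compound 1 to compound 4 (0.18 log units; within the scatter), so the exchange alone does not reproduce the earlier step, a 3.8-fold higher number from compound 1 to compound 2 (0.57 log units; beyond the scatter). With hydroxy kept at the chain end, 2-hydroxyethyl in place of hydroxy gives a 2.5-fold lower number from compound 2 to compound 4 (0.40 log units; beyond the scatter), which shows that the chain itself bears on the number. No measured evidence on the cause of these steps is at hand. Going by these compounds, whether an amine or a carboxylic acid at this chain end, or a longer chain, would move the number remains open.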